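A few compounds are considered here, and "the series" means these few. Any claim that something is new, unique, unknown or untested is made for them only; others in the source may bear on it.

Compound 1 `CC1=CC[C@@H]([C@@](C)(O)CCCC(C)(C)NC(=S)NN)CC1`: 9580 nM
Compound 2 `CC1=CC[C@@H]([C@@](C)(O)CCCC(C)(C)NC(=S)N/N=C\c2ccccc2)CC1`: > 100000 nM
Compound 3 `COc1ccc(/C=N\NC(=S)NC(C)(C)CCC[C@](C)(O)[C@@H]2CC=C(C)CC2)cc1`: > 100000 nM

In a functional assay on K562 cells (Homo sapiens) for cytotoxicity, read by sulforhodamine B assay (a higher number here means that more compound is tolerated, a lower number that less compound is tolerated), compound 1 gives 9580 nM. For compound 2 the value > 100000 nM is a limit of the assay, not a measured number. For compound 3 the value > 100000 nM is likewise a limit. Compound 3 therefore stands at the limit of > 100000 nM in this assay, at which 2 of the 3 values shown sit. Compound 4 `CC1=CC[C@@H]([C@@](C)(O)CCCC(C)(C)NC(=S)N/N=C\c2ccc(O)cc2)CC1` differs from compound 3 by hydrogen in place of methyl on an oxygen on an aromatic ring. The measured steps that bear on this part of the molecule are an at least 10-fold higher number from compound 1 to compound 2 (1.01 log units; beyond the scatter) and an at least 10-fold higher number from compound 1 to compound 3 (1.01 log units; beyond the scatter), both large; between the two aryl groups, a step that the two limits leave unreadable from compound 2 to compound 3. Going by the values given here, no measured step shows what swapping methoxy for hydroxy does. Compound 4 is expected to stay near the limit, at an estimated 100000 nM, plausibly between 30000 nM and 200000 nM. The expected step is therefore a number no higher from compound 3 to compound 4 (the limit leaves the size open).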

Compound 4, concentration lethal to 50% of the cells: > 100000 nM
Compound 4: only a limit was reported; the forecaster's own chance of this, stated with the estimate: 65%; the middle value lies on the limit itself.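

In this assay compound 4 gives > 100000 nM as a limit of the assay, not a number. Hydroxy on the aromatic ring does not bring back a measurable value, and the group bearing 4-hydroxyphenyl, set against the nitrogen of compound 1, gives an at least 10-fold higher number from compound 1 to compound 4 (1.01 log units; beyond the scatter) in line with the phenyl and 4-methoxyphenyl compounds. The steps among compound 2, compound 3 and compound 4 cannot be read, and all three stand at one value: the limit of > 100000 nM in this assay, at which 3 of the 4 values shown sit. Going by these compounds, it remains open whether an amine or a carboxylic acid on the aromatic ring would give a measurable value. A longer chain in place of the ring is equally untested here.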